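The compounds below may be only part of what the source reports. "The series", "measured", "known", "first", "only" and "open" are said of these compounds alone.

Measured so far in an ADME assay on Vero cells (Chlorocebus sabaeus) for cytotoxicity, read by MTT assay, with a stated time of 72 h; on this read-out higher numbers stand for weaker inhibition and lower numbers for stronger inhibition:
- compound 1 `CC(=O)N1N=C(c2ccc(-n3c(C)ccc3C)cc2)OC1c1ccccc1Cl` gives 201000 nM
- compound 2 `c1ccc(-c2nnc(-c3ccc(-n4cccc4)cc3)o2)cc1` gives 250000 nM
- compound 3 `O=[N+]([O-])c1cccc(-c2nnc(-c3ccc(-n4cccc4)cc3)o2)c1` gives 251000 nM

All three numbers sit close together. Compound 2 stands in the middle of this narrow cluster: its nearest neighbour is compound 3, reached by a 1.0-fold higher number from compound 2 to compound 3 (0.00 log units; within the scatter), and its furthest is compound 1, whose value differs from that of compound 2 by an amount that is also within the scatter. Nothing among these three therefore separates one compound from another.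

Compound 4 `Brc1ccccc1-c1nnc(-c2ccc(-n3cccc3)cc2)o1` has not yet been measured. It differs from compound 2 in a single place: bromo in place of hydrogen on an aromatic carbon. Among the compounds with values here, only one measured step speaks to a substituent entering a bare aromatic carbon of this kind, and that is a 1.0-fold higher number from compound 2 to compound 3 (0.00 log units; within the scatter), where a nitro group went onto an aromatic carbon with no change beyond the scatter. A bromo group is a different substituent in a different place, so this comparison is loose, but it is the only one available. On that basis the step from compound 2 to compound 4 in this assay is expected to be a 1.1-fold lower number from compound 2 to compound 4 (0.04 log units; within the scatter), that is, no shift beyond the scatter. Compound 4 is therefore estimated at 230000 nM, with a plausible range from 120000 nM to 450000 nM.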

Compound 4, half-maximal inhibitory concentration: 258000 nM
The estimate for compound 4 lay 1.1-fold (0.05 log units) below the measured number; measured number inside the range.
By their numbers in this assay, from the lowest: compounds 1, 2, 3 and 4 (each within the scatter of the next).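

In this assay, placing a bromo group on an aromatic carbon ortho to a large group, which turns phenyl into 2-bromophenyl, gives a 1.0-fold higher number from compound 2 to compound 4 (0.01 log units; within the scatter), so this single added heavy atom produces no shift that can be told apart from repeat-measurement noise. The earlier nitro change, a 1.0-fold higher number from compound 2 to compound 3 (0.00 log units; within the scatter), sat at a different place on the ring, so this result adds a second substituent and a second position on that phenyl ring where replacing a hydrogen leaves the number within the scatter. No measurement shown offers an explanation for this lack of a shift, and the result itself says only that none was seen.

Bromo and nitro are the only two replacements shown on this ring, so it remains open whether an amine, a carboxylic acid or a longer chain at the same carbon would also leave the number within the scatter. Going by these compounds, it is equally open whether a second substituent added to the 2-bromophenyl ring of compound 4 would move the number beyond the scatter.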